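Cytotoxicity of biaryl benzamides: a hydroxyphenyl analogue

This account rests on a few compounds, and the source may have more. Where it says the series, first, only, none or still open, it means among the compounds named here.

Compound 1, `CCOC(=O)CCCCCOc1cccc(CN(C(=O)c2ccc(-c3cnc(OC)nc3OC)cc2)C(C)C)c1`, in an ADME assay on Raji cells (Homo sapiens) for cytotoxicity, read by CellTiter-Glo and resazurin assay, with a stated time of 72 h (on this read-out lower numbers stand for an effect already at smaller amounts and higher numbers for an effect only at larger amounts of compound), gives > 26000 nM.
Compound 2, `CCOC(=O)CCCCCOc1cccc(CN(C(=O)c2ccc(-c3cccc(Oc4ccccc4)c3)cc2)C(C)C)c1`, in this assay gives > 19600 nM.
Compound 3, `CCOC(=O)CCCCCOc1cccc(CN(C(=O)c2ccc(-c3ccc4cc[nH]c4c3)cc2)C(C)C)c1`, in this assay gives > 26000 nM.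

Every number given for the three measured compounds is a limit of this assay, not a value. Compound 3 stands at the limit of > 26000 nM in this assay, at which 2 of the 3 values shown sit, and so does compound 1. Compound 2 stands at the limit of > 19600 nM in this assay, at which 1 of the 3 values shown sits. Among the compounds with values here, the one step among them, a step that the two limits leave unreadable from compound 1 to compound 3, is therefore unreadable, and no ordering of the three compounds can be drawn from these limits.

Compound 4, `CCOC(=O)CCCCCOc1cccc(CN(C(=O)c2ccc(-c3cccc(O)c3)cc2)C(C)C)c1`, differs from compound 3 by 3-hydroxyphenyl in place of 1H-indol-6-yl on an aromatic carbon. Within the data shown here, no measured step bears directly on this exchange, since the only step available is unreadable between its two limits. With every measured compound of the shared core sitting at a limit, the expectation for compound 4 in this assay is that it also yields a limit rather than a number, which would make a number no higher from compound 3 to compound 4 (the limit leaves the size open) unreadable as well. Compound 4 is therefore estimated at 26000 nM, with a range from 8000 nM to 60000 nM.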

Compound 4, half-maximal effective concentration: > 26000 nM
Compound 4: no number, only a limit; the forecaster's own chance of this, stated with the estimate: 85%; the middle value sits exactly at the limit.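

In this assay compound 4 gives > 26000 nM, a limit and not a number. Its steps from compound 1, compound 2 and compound 3 therefore cannot be read. The compounds shown leave open whether exchanging the group on the shared core changes the cytotoxicity read-out at all.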